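The source may report more compounds than this note shows. Statements on the series, on what has been measured and on what is new or still open speak of the compounds shown alone.

In a physicochemical assay for solubility (a lower number here means a less soluble compound, a higher number a more soluble compound), compound 1 `CCS(=O)(=O)c1ccc2c(c1)C(C)=CN(C)C(=O)[C@@H]2C` gives >= 131 ug/mL as a limit of the assay and not as a number. In this assay compound 2 `CCOc1ccc2c(c1)C(c1cn[nH]c1)=CN(C)C(=O)[C@@H]2C` gives >= 115 ug/mL as a limit as well. The standing of compound 2 is therefore known only as a limit, and the series has no exact reading yet to anchor on.

The next compound, compound 3 `CCOc1ccc2c(c1)C(c1c[nH]c(C)n1)=CN(C)C(=O)[C@@H]2C`, keeps the shared core of compound 2 and differs at one place. On a double-bonded ring carbon of the seven-membered non-aromatic ring, 2-methyl-1H-imidazol-4-yl stands in place of 1H-pyrazol-4-yl, and the counted difference is 2-methyl-1H-imidazol-4-yl in place of 1H-pyrazol-4-yl on a double-bonded ring carbon for this swap. Both groups are five-membered aromatic rings with 2 hetero atoms and no net charge.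

Among the compounds with values here, no step between measured compounds is available to size this swap, so no direction is favoured and no change beyond the usual scatter is expected. The expected step that the limit leaves unreadable from compound 2 to compound 3 is accordingly small. For compound 3 the estimated value is 120 ug/mL with an expected range from 60 ug/mL to 200 ug/mL in this assay when it is read.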

Compound 3, solubility: >= 135 ug/mL
Compound 3: a limit, no number; the forecaster's own chance of this, stated with the estimate: 55%; at least 1.1-fold (0.05 log units) between middle value and limit.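

In this assay compound 3 gives >= 135 ug/mL, a limit of the assay and not a number. Within the data shown here, compound 2 is also known only as a limit, so no step from compound 2 to compound 3 can be read. The compounds shown leave open the exact reading of each compound and whether 2-methyl-1H-imidazol-4-yl in place of 1H-pyrazol-4-yl changes the read-out at all.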